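This account rests on a few compounds, and the source may have more. Where it says the series, first, only, none or still open, it means among the compounds named here.

For the measured compounds named here, in an ADME assay on microsomes from liver (Homo sapiens) for metabolic stability, with a stated time of 10 min (a lower number here means that less of the compound is left, a higher number that more of the compound is left), compound 1 (`CC(=O)N1CC[C@H](C(=O)N2CC[C@](c3ccc(C(OCc4c(F)cccc4F)(C(F)(F)F)C(F)(F)F)cc3)(S(=O)(=O)c3ccc(F)cc3)C2)C1`) gives 19% and compound 2 (`CC(=O)N1CC[C@@H](C(=O)N2CC[C@](c3ccc(C(OCc4c(F)cccc4F)(C(F)(F)F)C(F)(F)F)cc3)(S(=O)(=O)c3ccc(F)cc3)C2)C1`) gives 9%, so compound 2 sits within the scatter of its only measured neighbour. Compound 3 (`O=C(O)C1CCN(C(=O)N2CC[C@](c3ccc(C(OCc4c(F)cccc4F)(C(F)(F)F)C(F)(F)F)cc3)(S(=O)(=O)c3ccc(F)cc3)C2)CC1`) carries 4-carboxypiperidin-1-yl in place of 1-acetylpyrrolidin-3-yl on a carbonyl carbon. Going by the values given here, the one measured step, a number 10 percentage points lower from compound 1 to compound 2 (within the scatter), bears on this only indirectly. Among the compounds with values here, it concerns the group that leaves, but it reflects a difference in configuration alone (the fact that compounds 1 and 2 differ only in the configuration as drawn), and no measured step replaces that group. Its size therefore gives little guide to the new change. With compound 2 at 9%, there is far more room for a rise than for a fall, so an upward move beyond the scatter is expected, though with wide uncertainty. The estimated step is a number 41 percentage points higher from compound 2 to compound 3 (beyond the scatter). For compound 3, the expected value in this assay is 50%, with an estimated range from 18% to 88%.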

Compound 3, percent of the compound remaining: 72%
The estimate for compound 3 lay 22 percentage points below the measured number; low and high end bracket the measured number.
By their numbers in this assay, from the lowest: compounds 2 and 1 (each within the scatter of the next); then compound 3.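

In this assay, putting 4-carboxypiperidin-1-yl in place of 1-acetylpyrrolidin-3-yl on a carbonyl carbon gives a number 63 percentage points higher from compound 2 to compound 3 (beyond the scatter) and a number 53 percentage points higher from compound 1 to compound 3 (beyond the scatter). This shows that the read-out at this position can move well beyond the scatter when the group itself is replaced, which the earlier pair could not show. The rise appears from both starting compounds, and these two are separated by configuration alone: the fact that compounds 1 and 2 differ only in the configuration as drawn

The change replaces the ring, the way it is attached to the carbonyl carbon and the end group all at once, so the compounds shown do not separate the share of each. From the compounds shown here alone, it also remains open what a methyl ester or a primary amide on the six-membered ring, or a carboxylic acid on the five-membered ring, would give.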